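The compounds below may be only part of what the source reports. "The series", "measured", "known", "first", "only" and "open" are said of these compounds alone.

Measured compounds:

Compound 1, `CCOC(=O)/C=C/c1cc(OC)ccc1OC(=O)c1nc(C)c(C)nc1C`, gives 46.2% in a functional assay on EA.hy 926 cells (Homo sapiens) for cytotoxicity, read by MTT assay, with stated times of 24 h and 12 h, tested at 100 uM; on this read-out higher numbers stand for a stronger effect at the one concentration tested and lower numbers for a weaker effect.
Compound 2, `CCOC(=O)/C=C/c1ccc(OC(=O)c2nc(C)c(C)nc2C)c(OC)c1`, gives 71.6% in this assay.
Compound 3, `CCOC(=O)/C=C/c1ccc(OC(=O)c2nc(C)c(C)nc2C)cc1`, gives 96.1% in this assay.

Compound 1 has the lowest of the three numbers. Compound 1 and compound 2 share the same atoms joined differently; how their cores differ is not broken down here. From compound 2 to compound 3 the change is hydrogen in place of methoxy on an aromatic carbon, and it gave a number 24.5 percentage points higher from compound 2 to compound 3 (beyond the scatter).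

Compound 4, `CCOC(=O)/C=C/c1ccccc1OC(=O)c1nc(C)c(C)nc1C`, is not yet measured. It differs from compound 1 by hydrogen in place of methoxy on an aromatic carbon. This is the same kind of change as that from compound 2 to compound 3, though the surroundings differ: in compound 2 the methoxy sits ortho to a large group and meta to the 2-(ethoxycarbonyl)ethenyl group, whereas in compound 1 it sits meta to that group and para to a large group. Because the earlier step gave a number 24.5 percentage points higher from compound 2 to compound 3 (beyond the scatter), a similar rise is expected, so the step estimated is a number 23.8 percentage points higher from compound 1 to compound 4 (beyond the scatter). Compound 4 is therefore expected to reach about 70%, between 50% and 92%.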

Compound 4, a percentage reported as activity, at one concentration (the size of the read-out at that concentration, not a potency): 40.9%
The estimate for compound 4 lay 29.1 percentage points above the measured number, outside the stated range (below it).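

In this assay hydrogen in place of methoxy gave a number 5.3 percentage points lower from compound 1 to compound 4 (within the scatter) and so no clear change on the core of compound 1. The same replacement therefore did not act alike on the two cores: the same change on two cores in this assay, a number 24.5 percentage points higher (beyond the scatter) from compound 2 to compound 3 and a number 5.3 percentage points lower (within the scatter) from compound 1 to compound 4, 29.8 percentage points apart, beyond the scatter of two such steps

This shows that a rise seen on one core cannot simply be carried to the other in this series, but these two pairs do not show what sets the cores apart or how the change would behave on any further core.

The compounds shown hold only methoxy or hydrogen at the changed places, and all carry the ethyl ester. How a hydroxyl group in place of methoxy, or a carboxylic acid in place of that ester, would read in this assay is left open.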